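Swapping a Methylphenyl for a Naphthyl on the Shared Core

The source may hold more compounds than are shown below. What is called first, only, known or untested is meant among the compounds shown, and "the series" means these compounds.

Compound 1 `COc1ccc(-c2ccc3c(c2)C(=O)C(=O)N3Cc2ccccc2Cl)cc1`: 380 nM
Compound 2 `COc1ccc(-c2ccc3c(c2)C(=O)C(=O)N3Cc2ccc(C)cc2)cc1`: 270 nM

In a functional assay on K562 cells (Homo sapiens) for antiproliferative activity, read by MTT assay, with a stated time of 48 h (on this read-out higher numbers stand for weaker inhibition and lower numbers for stronger inhibition), compound 2 gives 270 nM and compound 1 gives 380 nM. Among the measured compounds shown here, the one measured step, a 1.4-fold lower number from compound 1 to compound 2 (0.15 log units; within the scatter), lies within the scatter, so neither compound stands apart from the other. Compound 3 `COc1ccc(-c2ccc3c(c2)C(=O)C(=O)N3Cc2ccc3ccccc3c2)cc1` differs from compound 2 by naphthalen-2-yl in place of 4-methylphenyl on a saturated chain carbon bound to an amide-type nitrogen in a ring. For the measured compounds named here, no measured step brings in a second ring; the only step, a 1.4-fold lower number from compound 1 to compound 2 (0.15 log units; within the scatter), swapped a different group at the same carbon without moving the number beyond the scatter. No step beyond the scatter is therefore expected here. Compound 3 is estimated at 250 nM, between 100 nM and 650 nM. That amounts to an expected step of a 1.1-fold lower number from compound 2 to compound 3 (0.03 log units; within the scatter).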

Compound 3, half-maximal inhibitory concentration: 400 nM
Estimate against measurement, compound 3: 1.6-fold (0.20 log units) below, and the stated range covers the measured number.
By their numbers in this assay, from the lowest: compounds 2, 1 and 3 (each within the scatter of the next).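

Naphthalen-2-yl brings a second six-membered aromatic ring to this position, yet this assay does not separate it from the single-ring groups: replacing 4-methylphenyl gives a 1.5-fold higher number from compound 2 to compound 3 (0.17 log units; within the scatter), and replacing 2-chlorophenyl gives a 1.1-fold higher number from compound 1 to compound 3 (0.02 log units; within the scatter). Across compounds 1, 2 and 3, then, this position accepts all three aromatic groups, including one with 10 heavy atoms, with no step beyond the scatter. Nothing measured here offers an explanation for this.

As far as these compounds go, whether an amine or a carboxylic acid on this saturated chain carbon would move the number beyond the scatter remains open. The same is true of a longer chain carrying one of these aromatic rings.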